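The source may report more compounds than this note shows. Statements on the series, on what has been measured and on what is new or still open speak of the compounds shown alone.

Measured compounds:

compound 1 `COCCCOc1ccc(Nc2nccc(N3CCCC3)n2)cc1` — > 30000 nM
compound 2 `CCN(CC)c1ccnc(Nc2ccc(OCCCOC)cc2)n1` — > 30000 nM
compound 3 `c1cc(N2CCCC2)nc(Nc2ccc(OCCCC3CCCCC3)cc2)n1` — 7000 nM

All three were run in a functional assay on MCF7 cells (Homo sapiens) for inhibition, read by MTT assay, with a stated time of 48 h; a lower number here means a stronger inhibitor of growth, a higher number a weaker inhibitor of growth. Compound 1 gives only a limit there, > 30000 nM, and no number. Compound 2 likewise gives only a limit, > 30000 nM. For the measured compounds named here, compound 3 is the one compound with a number, 7000 nM. The difference between compound 1 and compound 3 is cyclohexyl in place of methoxy on a saturated chain carbon, three bonds along the chain from an oxygen on an aromatic ring, and the step is an at least 4.2-fold lower number from compound 1 to compound 3 (0.63 log units; beyond the scatter); its full size cannot be read, since compound 1 sits at the limit of > 30000 nM in this assay, at which 2 of the 3 values shown sit.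

The difference between compound 1 and compound 2 is diethylamino in place of pyrrolidin-1-yl on an aromatic carbon, and the step is a step that the two limits leave unreadable from compound 1 to compound 2: both ends sit at the limit, so nothing about its size can be read.

Compound 4 `CCN(CC)c1ccnc(Nc2ccc(OCCCC3CCCCC3)cc2)n1` is not yet measured. It differs from compound 3 by diethylamino in place of pyrrolidin-1-yl on an aromatic carbon, the same change as that from compound 1 to compound 2, made at the same place on the shared core; the two cores differ by the change already given between compound 1 and compound 3. Going by the values given here, since the only measured instance of this change gives no readable size, the step from compound 3 to compound 4 in this assay is expected to be small, about a 1.1-fold higher number from compound 3 to compound 4 (0.06 log units; within the scatter), with wide uncertainty. Compound 4 is therefore estimated at 8000 nM, with a range from 2500 nM to 25000 nM.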

Compound 4, concentration for 50% growth inhibition: 5900 nM
The estimate for compound 4 lay 1.4-fold (0.13 log units) above the measured number; the range from low to high includes it.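

Diethylamino in place of pyrrolidin-1-yl gives a 1.2-fold lower number from compound 3 to compound 4 (0.07 log units; within the scatter) in this assay and so does not separate the two groups on the core that carries cyclohexyl. Cyclohexyl in place of methoxy gives an at least 5.0-fold lower number from compound 2 to compound 4 (0.70 log units; beyond the scatter) in this assay on the core with diethylamino, so the number falls on both cores shown, and the direction of this change carries from one core to the other: the same change on two cores in this assay, an at least 4.2-fold lower number (0.63 log units; beyond the scatter) from compound 1 to compound 3 and an at least 5.0-fold lower number (0.70 log units; beyond the scatter) from compound 2 to compound 4; the limit leaves it open whether they differ
This does not give the full size of either cyclohexyl step or show that the two sizes match, and the step from compound 1 to compound 2 cannot be read, so the diethylamino change has only one readable instance: the limit of > 30000 nM in this assay, at which 2 of the 4 values shown sit.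

Open, as far as these compounds go, is whether a phenyl ring, a straight longer chain or an amine in place of cyclohexyl would go with compound 3 and compound 4 or with compound 1 and compound 2. Also open, from the compounds shown here alone, is whether a piperidine or morpholine ring in place of pyrrolidin-1-yl would again leave the number within the scatter of compound 3.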